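A few compounds are considered here, and "the series" means these few. Any claim that something is new, unique, unknown or untested is made for them only; others in the source may bear on it.

Measured so far:
- compound 1 `O=C(CCN1CCN(c2ccc([N+](=O)[O-])cc2)CC1)c1ccc(Br)cc1` gives 79800 nM
- compound 2 `O=C(CCN1CCN(c2ccc(C(F)(F)F)cc2)CC1)c1ccc(OC(F)(F)F)cc1` gives 64900 nM

In an ADME assay on Vero cells (Chlorocebus sabaeus) for cytotoxicity, read by resazurin assay, with a stated time of 72 h (a lower number here means a stronger inhibitor, a higher number a weaker inhibitor), compound 2 stands at 64900 nM and compound 1 at 79800 nM, two values within the scatter of each other.

Compound 3 `O=C(CCN1CCN(c2ccc([N+](=O)[O-])cc2)CC1)c1ccc(OC(F)(F)F)cc1` differs from compound 2 by nitro in place of trifluoromethyl on an aromatic carbon, para to a large group (nitro in place of trifluoromethyl on an aromatic carbon). Within the data shown here, compound 1 also carries 4-nitrophenyl and compound 2 carries 4-(trifluoromethyl)phenyl, but the two differ elsewhere too, so no measured step isolates this change. With compound 1 at 79800 nM and compound 2 at 64900 nM, no step beyond the scatter is expected in this assay. The estimate amounts to a 1.1-fold higher number from compound 2 to compound 3 (0.03 log units; within the scatter). For compound 3 the expected value is 70000 nM, with an estimated range of 35000 nM to 125000 nM.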

Compound 3, half-maximal inhibitory concentration: 93200 nM
Compound 3: middle estimate off by 1.3-fold (0.12 log units), on the low side, and the stated range covers the measured number.
By their numbers in this assay, from the lowest: compounds 2, 1 and 3 (each within the scatter of the next).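

In this assay, among these compounds, nitro in place of trifluoromethyl on an aromatic carbon, para to a large group, gives a 1.4-fold higher number from compound 2 to compound 3 (0.16 log units; within the scatter) and so gives the first isolated reading at this position, with no step beyond the scatter. The second single change, trifluoromethoxy in place of bromo on an aromatic carbon, gives a 1.2-fold higher number from compound 1 to compound 3 (0.07 log units; within the scatter) and is also no step beyond the scatter, so neither change separates these three compounds in this read-out. Nothing at hand bears on the origin of these small steps.

As far as these compounds go, only nitro and trifluoromethyl are compared at the position para to a large group, so it remains open whether an amine or a carboxylic acid there would give a step beyond the scatter. From the compounds shown here alone, the effect of a longer chain in the linker between the two aromatic ends also remains open.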